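The source may hold more compounds than are shown below. What is called first, only, known or untested is meant among the compounds shown, and "the series" means these compounds.

Compound 1 `O=C(/C=C/c1ccc(O)c(O)c1)N1CCN(c2ccccc2F)CC1`: 1.43 ug/mL
Compound 2 `O=C(/C=C/c1ccc(O)c(O)c1)N1CCN(c2cccc(Cl)c2)CC1`: 1.29 ug/mL

Among the compounds with values here, in a functional assay on A549 cells (Homo sapiens) for antiproliferative activity, read by MTT assay, with a stated time of 48 h (on this read-out lower numbers stand for stronger inhibition and higher numbers for weaker inhibition), compound 2 gives 1.29 ug/mL, which lies within the scatter of compound 1, the only other compound measured. Compound 3 `O=C(/C=C/c1ccc(O)c(O)c1)N1CCN(c2ccc([N+](=O)[O-])cc2)CC1` has not yet been measured. It carries 4-nitrophenyl in place of 3-chlorophenyl on an amine nitrogen in a ring. Within the data shown here, only one measured step bears on this change, a 1.1-fold lower number from compound 1 to compound 2 (0.04 log units; within the scatter). It exchanged the group at the same place and stayed within the scatter, though it involved no nitro group. No shift in either direction beyond the scatter is therefore expected, and the estimated change is a 1.1-fold higher number from compound 2 to compound 3 (0.04 log units; within the scatter). Compound 3 is expected at 1.4 ug/mL, with an estimated range of 0.6 ug/mL to 3.5 ug/mL.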

Compound 3, half-maximal inhibitory concentration: 1.56 ug/mL
Compound 3: the middle estimate sits 1.1-fold (0.05 log units) below what was measured; the range from low to high includes it.
By their numbers in this assay, from the lowest: compounds 2, 1 and 3 (each within the scatter of the next).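

The steps of a 1.2-fold higher number from compound 2 to compound 3 (0.08 log units; within the scatter) and a 1.1-fold higher number from compound 1 to compound 3 (0.04 log units; within the scatter) show that in this assay this place on the ring nitrogen also accepts 4-nitrophenyl, which brings hydrogen-bond acceptors and a double bond outside aromatic rings, without leaving the scatter. All three substituted phenyl groups shown therefore give numbers within the scatter of one another. Nothing measured here accounts for this. On these data alone, whether a carboxylic acid or an amine on the phenyl ring, or a longer chain in place of that ring, would move the number remains open. The compounds shown also say nothing about changes elsewhere on the shared core.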